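Restoring the Nitrogen Link While Dropping Two Methyl Groups

The source may hold more compounds than are shown below. What is called first, only, known or untested is meant among the compounds shown, and "the series" means these compounds.

Measured so far:
- compound 1, `CCCCCCCC/C=C\CCCCCCCCNC(=O)Nc1c(C)cccc1C`: 160 nM
- compound 2, `CCCCCCCC/C=C\CCCCCCCC/N=C(\S)Nc1c(C)cccc1C`: 5400 nM
- compound 3, `CCCCCCCC/C=C\CCCCCCCCNC(=O)c1c(C)cccc1C`: 9800 nM

In an assay on microsomes from intestinal mucosa for inhibition of acyl-CoA:cholesterol acyltransferase (Oryctolagus cuniculus) (on this read-out higher numbers stand for weaker inhibition and lower numbers for stronger inhibition), compound 3 gives the highest number of the three. Compound 2 sits close to it, within the usual scatter, so no order between compound 2 and compound 3 can be claimed. For the measured compounds named here, compound 1 lies far below, and the one measured step that connects it to compound 3 is a 61-fold higher number from compound 1 to compound 3 (1.79 log units; beyond the scatter), a large move towards weaker inhibition when the (2,6-dimethylphenyl)amino group was replaced by 2,6-dimethylphenyl on the carbonyl carbon.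

Compound 4, `CCCCCCCC/C=C\CCCCCCCCNC(=O)Nc1ccccc1`, has not yet been measured. It differs from compound 3 in one place: anilino in place of 2,6-dimethylphenyl on a carbonyl carbon. This change brings back a nitrogen between the carbonyl carbon and the aromatic ring, as in compound 1, but the ring now carries no methyl groups. Going by the values given here, no measured pair shows what removing those two methyl groups does on its own, so that part of the change is unknown.

Because the step of a 61-fold higher number from compound 1 to compound 3 (1.79 log units; beyond the scatter) was large, the return of the nitrogen link is expected to lower the number markedly, giving an estimated 20-fold lower number from compound 3 to compound 4 (1.29 log units; beyond the scatter). The missing methyl groups add uncertainty, so the expected value for compound 4 is 500 nM, with a range from 100 nM to 3000 nM.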

Compound 4, half-maximal inhibitory concentration: > 5000 nM
Compound 4: no number, only a limit; the forecaster's own chance of this, stated with the estimate: 5%; middle value at least 10-fold (1.00 log units) away from the limit.
By their numbers in this assay, from the lowest: compound 1; then compounds 2 and 3 (each within the scatter of the next).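

In this assay compound 4 gives > 5000 nM, which is a limit of the assay and not a number: the limit of > 5000 nM in this assay, at which 1 of the 4 values shown sits.

For the compounds shown here, compounds 1 and 4 differ only in the two methyl groups on the aromatic ring, so this pair is the first to isolate what those groups contribute, and the result is an at least 31-fold higher number from compound 1 to compound 4 (1.49 log units; beyond the scatter), a large move towards weaker inhibition. Restoring the nitrogen link to the carbonyl carbon is therefore not enough on its own to reach the low number of compound 1, which in this series also requires 2,6-dimethylphenyl rather than phenyl on the amide-type nitrogen; the step from compound 3 to compound 4 cannot be read against the limit, so no order between those two compounds can be stated.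

From the compounds shown here alone, it remains open whether a single methyl group on the ring would be enough, and whether isopropyl or chlorine in place of the two methyl groups would keep, lower or raise the number of compound 1. Going by these compounds, it is also open how a shorter chain in place of the long chain shared by these compounds would change the read-out.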